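The compounds below may be only part of what the source reports. "The series", "measured", "known", "first", "only" and "open" are said of these compounds alone.

Within the data shown here, in a functional assay on A549 cells (Homo sapiens) for inhibition, read by CCK-8 assay, with a stated time of 72 h, tested at 1 uM (on this read-out higher numbers stand for more inhibition of growth at the one concentration tested and lower numbers for less inhibition of growth), compound 1 `CN(C)C(=O)c1cc2cnc(Nc3ccc(NC(=O)C4(C(=O)Nc5cccc(F)c5)CC4)cc3)nc2n1C1CCCC1` gives 33.2%, the highest of the three numbers measured so far. Compound 2 `CN(C)C(=O)c1cc2cnc(Nc3ccc(NC(=O)C4(C(=O)Nc5ccc(Br)cc5)CC4)cc3)nc2n1C1CCCC1` gives -6.6%, while, lacking the core of compound 1, compound 3 `Nc1ccc(NC(=O)C2(C(=O)Nc3ccc(F)cc3)CC2)cc1F` gives 16.3%. The untested compound 4 `CN(C)C(=O)c1cc2cnc(Nc3ccc(NC(=O)C4(C(=O)Nc5ccc(Cl)c(C(F)(F)F)c5)CC4)cc3)nc2n1C1CCCC1` has 4-chloro-3-(trifluoromethyl)phenyl in place of 3-fluorophenyl on an amide-type nitrogen. Among the measured compounds shown here, the only measured step at that place is a number 39.8 percentage points lower from compound 1 to compound 2 (beyond the scatter), which put 4-bromophenyl there and is large. A single step is thin evidence, so a fall of moderate size is expected in this assay. The expected step is a number 23.2 percentage points lower from compound 1 to compound 4 (beyond the scatter). For compound 4 the estimated value is 10%, with an expected range from -12% to 35%.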

Compound 4, percent growth inhibition at one concentration: 1.1%
Beside the measured number, compound 4's estimate is 8.9 percentage points above it, within the range that was stated.
By their numbers in this assay, from the lowest: compounds 2 and 4 (each within the scatter of the next); then compound 3; then compound 1.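

A second replacement at this amide-type nitrogen also brings a large fall (a number 32.1 percentage points lower from compound 1 to compound 4 (beyond the scatter)), so the loss seen with 4-bromophenyl is not limited to that one group. The two replacements cannot be told apart (a number 7.7 percentage points higher from compound 2 to compound 4 (within the scatter)), even though 4-chloro-3-(trifluoromethyl)phenyl is the larger group, and 3-fluorophenyl stands apart from both. Nothing available here explains these falls. Still open, as far as these compounds go, is whether a plain phenyl, a 3-chlorophenyl or a 3-aminophenyl at this nitrogen would keep the inhibition of compound 1.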